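Hydroxynaphthyl in place of hydroxyphenyl at the hydrazone carbon

A few compounds are considered here, and "the series" means these few. Any claim that something is new, unique, unknown or untested is made for them only; others in the source may bear on it.

Compound 1 `CN(C)CCn1cnnc1-c1cc(Oc2ccc(NC(=O)N/N=C/c3cccc(O)c3)cc2F)ccn1` is not placed by a number in a functional assay on A549 cells (Homo sapiens) for cytotoxicity, read by MTT assay, with a stated time of 72 h; a lower number here means a stronger inhibitor, a higher number a weaker inhibitor: the value for compound 1, > 100000 nM, is a limit of the assay. Compound 2 `CN(C)CCn1cnnc1-c1cc(Oc2ccc(NC(=O)N/N=C/c3ccc(F)cc3Cl)cc2F)ccn1` gives 1120 nM in this assay. Compound 3 `CN(C)CCn1cnnc1-c1cc(Oc2ccc(NC(=O)N/N=C/c3cc(Br)c(O)c(Br)c3)cc2F)ccn1` again returns a limit, > 100000 nM. Two of the three steps read: an at least 89-fold lower number from compound 1 to compound 2 (1.95 log units; beyond the scatter) and an at least 89-fold higher number from compound 2 to compound 3 (1.95 log units; beyond the scatter); the third, a step that the two limits leave unreadable from compound 1 to compound 3, cannot be sized. Both compounds with a hydroxyl on the ring attached to the carbon with a double bond to nitrogen sit at the limit of > 100000 nM in this assay, at which 2 of the 3 values shown sit, while only compound 2, with its halogenated ring, yields a number.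

Compound 4 `CN(C)CCn1cnnc1-c1cc(Oc2ccc(NC(=O)N/N=C/c3c(O)ccc4ccccc34)cc2F)ccn1` differs from compound 1 in one place: 2-hydroxynaphthalen-1-yl in place of 3-hydroxyphenyl on a carbon with a double bond to nitrogen. For the measured compounds named here, the hydroxyl is retained and the ring system enlarged; none of the measured steps covers this change directly, and the only step with a read size moves away from a hydroxyl-bearing ring, not toward a larger one. Compound 4 is therefore expected to remain near the limit, with the step from compound 1 estimated as a number no higher from compound 1 to compound 4 (the limit leaves the size open). The expected value for compound 4 in this assay is 100000 nM, within 20000 nM to 300000 nM.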

Compound 4, half-maximal inhibitory concentration: 880 nM
Compound 4: the middle estimate sits 110-fold (2.06 log units) above what was measured; measured number below the stated range.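

In this assay, a hydroxyl-bearing ring on the carbon with a double bond to nitrogen is no longer tied to the limit: 2-hydroxynaphthalen-1-yl gives an at least 110-fold lower number from compound 1 to compound 4 (2.05 log units; beyond the scatter) and an at least 110-fold lower number from compound 3 to compound 4 (2.05 log units; beyond the scatter). Compound 4 keeps a hydroxyl and compound 2 has none, yet the step between them, a 1.3-fold lower number from compound 2 to compound 4 (0.10 log units; within the scatter), does not separate them, so a halogenated ring is not the only route to a measurable value in this set. The hydroxyl alone therefore does not account for compound 1 and compound 3 sitting at a limit: the limit of > 100000 nM in this assay, at which 2 of the 4 values shown sit.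

The enlarged ring and the changed hydroxyl place arrive together in compound 4, so naphthalen-1-yl and 2-hydroxyphenyl would be needed to part the two. As far as these compounds go, how an amine or a carboxylic acid on this ring would read remains open.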